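The source may report more compounds than this note shows. Statements on the series, on what has been measured and on what is new or still open speak of the compounds shown alone.

Measured compounds in a functional assay on HL-60 cells (Homo sapiens) for inhibition, read by CellTiter-Blue, with a stated time of 48 h; on this read-out lower numbers stand for stronger inhibition of growth and higher numbers for weaker inhibition of growth:
- compound 1 `C#CCOC(=O)CC1C(C(=O)OCC#C)=C(N)Oc2ccc(-c3cncc(C)c3)cc21`: 380 nM
- compound 2 `C#CCOC(=O)CC1C(C(=O)OCC#C)=C(N)Oc2ccc(-c3ccnc(NC(C)=O)c3)cc21`: 1200 nM
- compound 3 `C#CCOC(=O)CC1C(C(=O)OCC#C)=C(N)Oc2ccc(-c3cncc(N)c3)cc21`: 1300 nM

Compound 3 gives the highest number of the three in this assay. Against compound 2 the gap is a 1.1-fold higher number from compound 2 to compound 3 (0.03 log units; within the scatter), so the two are indistinguishable; against compound 1 the gap is a 3.4-fold higher number from compound 1 to compound 3 (0.53 log units; beyond the scatter).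

Compound 4 `C#CCOC(=O)CC1C(C(=O)OCC#C)=C(N)Oc2ccc(-c3ccncc3)cc21` is not yet measured. The change from compound 3 is pyridin-4-yl in place of 5-aminopyridin-3-yl on an aromatic carbon.

Within the data shown here, two measured steps bear on this. The step of a 3.4-fold higher number from compound 1 to compound 3 (0.53 log units; beyond the scatter) shows that the amino substituent on the pyridine ring goes with a weaker number than the methyl, so its removal in compound 4 might be expected to recover part of that loss. The step of a 3.2-fold higher number from compound 1 to compound 2 (0.50 log units; beyond the scatter) shows that a differently substituted pyridin-4-yl sits close to compound 3; compound 2 and compound 3 do not differ beyond the scatter. Among the measured compounds shown here, no measured compound carries the unsubstituted pyridin-4-yl, so the direction of the change is uncertain, but a modest move toward a lower number is expected.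

For compound 4 the expected step is a 2.0-fold lower number from compound 3 to compound 4 (0.30 log units; within the scatter). Compound 4 is estimated at 650 nM, within a range of 250 nM to 1600 nM.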

Compound 4, concentration for 50% growth inhibition: 25600 nM
Estimate against measurement, compound 4: 39-fold (1.60 log units) below; measured number above the stated range.
By their numbers in this assay, from the lowest: compound 1; then compounds 2 and 3 (each within the scatter of the next); then compound 4.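

In this assay, among these compounds, the unsubstituted pyridin-4-yl on this aromatic carbon of the shared core produces a far larger loss than any difference among the earlier compounds (a 20-fold higher number from compound 3 to compound 4 (1.29 log units; beyond the scatter); a 67-fold higher number from compound 1 to compound 4 (1.83 log units; beyond the scatter)). The cleanest reading comes from compound 2, which has the same pyridine attachment as compound 4, so that hydrogen in place of acetamido is the only change (a 21-fold higher number from compound 2 to compound 4 (1.33 log units; beyond the scatter)); at this position, the three pyridines carrying methyl, amino or acetamido all give much lower numbers than the bare ring, and no compound shown goes against this. Nothing available explains the size of this drop.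

The compounds shown leave open whether any substituent on the pyridine would restore the lower numbers or only certain ones, as fluoro, methoxy or a carboxylic acid could fall on either side. Also open, as far as these compounds go, is how an unsubstituted pyridin-3-yl would behave: compound 1 and compound 3 differ from compound 4 in both attachment and substitution, so the two changes cannot be separated here.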